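The compounds below may be only part of what the source reports. "The series", "measured", "known", "first", "only" and "open" are said of these compounds alone.

Two compounds of this series have a measured value in a physicochemical assay for solubility, read by LC-MS, in phosphate buffer, measured as thermodynamic solubility, with a stated time of 24 h, at pH 7.4; a lower number here means a less soluble compound, a higher number a more soluble compound. Compound 1 `Cc1ccc(S(=O)(=O)n2cc(-c3cccc(C#N)c3)c3cc(-c4cnn(C)c4)cnc32)cc1` gives 700 nM, and compound 2 `N#Cc1cccc(-c2c[nH]c3ncc(N4CCCC4)cc23)c1` gives 300 nM, the lower of the two numbers, separated from compound 1 by a gap beyond the usual scatter. Compound 3 `Cn1cc(Nc2cnc3[nH]cc(-c4cccc(C#N)c4)c3c2)cn1` differs from compound 2 in one place: (1-methyl-1H-pyrazol-4-yl)amino in place of pyrrolidin-1-yl on an aromatic carbon. Within the data shown here, no measured pair shows this change, so the direction can only be expected, not read off. For compound 3 in this assay an upward step is expected, a 2.0-fold higher number from compound 2 to compound 3 (0.30 log units; within the scatter), giving an estimate of 600 nM within a range from 200 nM to 2000 nM.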

Compound 3, solubility: 31000 nM
Estimate against measurement, compound 3: 52-fold (1.71 log units) below; the measured number lies above the stated range.
By their numbers in this assay, from the lowest: compound 2; then compound 1; then compound 3.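

In this assay, (1-methyl-1H-pyrazol-4-yl)amino in place of pyrrolidin-1-yl on this aromatic carbon gives a 100-fold higher number from compound 2 to compound 3 (2.01 log units; beyond the scatter) as a large step. Among these compounds, this is the first pair differing in one place, and it shows that a single change at this position can move the number far beyond the scatter. Nothing given here accounts for the step. The compounds shown do not separate the contributions of the linking amino group, the pyrazole ring and its methyl. From the compounds shown here alone, how a morpholin-4-yl group or a plain amino group would read at this position remains open.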